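This account rests on a few compounds, and the source may have more. Where it says the series, first, only, none or still open, it means among the compounds named here.

Compound 1 `Cc1ccc(NC2=C/C(=N/NC(N)=S)C(=O)N=C2Nc2ccc(C)cc2)cc1` and compound 2 `NC(=S)N/N=C1/C=C(Nc2ccc(Cl)cc2)C(Nc2ccc(Cl)cc2)=NC1=O` were both examined in a functional assay on MCF7 cells (Homo sapiens) for antiproliferative activity, read by MTT assay, with a stated time of 72 h; a higher number here means a weaker inhibitor, a lower number a stronger inhibitor. In that setting compound 1 gives 3060 nM, while compound 2 gives 1370 nM, the lowest of the three numbers measured; the difference between the two cores is not broken down here. Compound 3 `Cc1ccc(NC2=C/C(=N/N=C(\N)SCc3ccccc3)C(=O)N=C2Nc2ccc(C)cc2)cc1` differs from compound 1 by a group of 11 heavy atoms (8 carbon, 2 nitrogen, 1 sulfur; one six-membered aromatic ring of carbon only) in place of a group of 4 heavy atoms (1 carbon, 2 nitrogen, 1 sulfur; no ring), on a double-bonded nitrogen. In this assay compound 3 gives 13400 nM, so that the change produced a 4.4-fold higher number from compound 1 to compound 3 (0.64 log units; beyond the scatter). Compound 4 `N/C(=N\N=C1\C=C(Nc2ccc(Cl)cc2)C(Nc2ccc(Cl)cc2)=NC1=O)SCc1ccccc1` carries the same change made on the core of compound 2, namely (a group of 11 heavy atoms (8 carbon, 2 nitrogen, 1 sulfur; one six-membered aromatic ring of carbon only) in place of a group of 4 heavy atoms (1 carbon, 2 nitrogen, 1 sulfur; no ring), on a double-bonded nitrogen); the place it sits on is described in the same words for both pairs. For the measured compounds named here, only this one measured step is available, so the expectation for compound 4 rests on it alone and is worded as an expectation. Going by the values given here, compound 4 is expected to show a step of a 4.4-fold higher number from compound 2 to compound 4 (0.64 log units; beyond the scatter), a move of about the same size and direction as the one seen from compound 1 to compound 3. The estimated value for compound 4 in this assay is 6000 nM, most likely falling between 2500 nM and 15000 nM.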

Compound 4, half-maximal inhibitory concentration: 7720 nM
Beside the measured number, compound 4's estimate is 1.3-fold (0.11 log units) below it; low and high end bracket the measured number.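

In this assay, putting the larger group on the double-bonded nitrogen of the core of compound 2 gives a 5.6-fold higher number from compound 2 to compound 4 (0.75 log units; beyond the scatter) and so moves the number in the same direction as it moved on the core of compound 1. The same change therefore carries over between these two cores, and the size of its effect agrees as well: the same change on two cores in this assay, a 4.4-fold higher number (0.64 log units; beyond the scatter) from compound 1 to compound 3 and a 5.6-fold higher number (0.75 log units; beyond the scatter) from compound 2 to compound 4, 1.3-fold (0.11 log units) apart, within the scatter of two such steps. This rests on one pair on each core, so it shows that the change behaves alike on these two cores only; it does not show that the same would hold on any other core, and it does not explain why the number rises.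

The compounds shown leave open whether a smaller or different group on the sulfur, such as a methyl, an ethyl chain or a carboxylic acid-bearing chain, would give a step of similar size. They also leave open whether the change would carry over to a core bearing a methoxy or fluoro group on its outer rings in place of the methyl or chloro.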